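A Second Methyl on the Core of Compound 1

A few compounds are considered here, and "the series" means these few. Any claim that something is new, unique, unknown or untested is made for them only; others in the source may bear on it.

In a functional assay on MDA-MB-231 cells (Homo sapiens) for antiproliferative activity, read by MTT assay (a lower number here means a stronger inhibitor, a higher number a weaker inhibitor), compound 1 `CC/C=C\C/C=C\C/C=C\CCCCCCCc1cc(=O)c2c(O)cc(O)cc2o1` gives 6790 nM. Compound 2 `CC/C=C\C/C=C\C/C=C\CCCCCCCc1cc(=O)c2c(O)c(C)c(O)cc2o1` gives 6790 nM, and compound 3 `CCCC/C=C\CCCCCCCCCc1cc(=O)c2c(O)cc(O)cc2o1` gives 6790 nM, so compound 1 stands level with both of them.

Compound 4 `CC/C=C\C/C=C\C/C=C\CCCCCCCc1cc(=O)c2c(O)cc(O)c(C)c2o1` has not yet been measured. It differs from compound 1 in one place: methyl in place of hydrogen on an aromatic carbon. In words, this is methyl in place of hydrogen on an aromatic carbon, here one that is ortho to a hydroxy group and para to a hydroxy group.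

Going by the values given here, two measured steps bear on this. The closer precedent is no change at the digits printed from compound 1 to compound 2 (within the scatter), which is also methyl in place of hydrogen on an aromatic carbon, though at a different carbon of the core. The other, no change at the digits printed from compound 1 to compound 3 (within the scatter), alters the chain and leaves the core alone, so it says less about this change. Both steps lie within the scatter. Among the compounds with values here, still, this is thin evidence, and no measurement yet covers a methyl at the new carbon.

The step expected in this assay is therefore no change at the digits printed from compound 1 to compound 4 (within the scatter), with no size beyond the scatter and no favoured direction. For compound 4 the estimated value is 6790 nM, with an expected range from 3000 nM to 13000 nM.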

Compound 4, half-maximal inhibitory concentration: 6790 nM
The estimate for compound 4 equals the measured number at the digits printed; measured number inside the range.
By their numbers in this assay, from the lowest: compounds 1, 2, 3 and 4 (each within the scatter of the next).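

In this assay, going by these compounds alone, a methyl on this carbon gives no change at the digits printed from compound 1 to compound 4 (within the scatter); this is the first reading at a carbon that is ortho to a hydroxy group and para to a hydroxy group. Read with no change at the digits printed from compound 1 to compound 2 (within the scatter), it means that methyl in place of hydrogen has now been tested at two different carbons of the shared core, and neither step goes beyond the scatter. This result therefore extends what compound 2 showed for one carbon to a second carbon, but it speaks only for a methyl at these two places and only in this cell assay.

Still open, on these data alone, is whether a larger or differently built group at this carbon, such as an ethyl, a methoxy, an amine or a carboxylic acid, would stay level with compound 1, and whether methyl groups on both carbons at once would do so. Nothing among the data shown gives a reason for this result.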